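The source may report more compounds than this note shows. Statements on the series, on what has been measured and on what is new or still open speak of the compounds shown alone.

Of the compounds shown here, three sharing one core have so far been tested in a functional assay on the whole organism for inhibition, with Rattus norvegicus as the target, read by paw edema, with stated times of 30 min and 4 h, at a dose of 10 mg/kg by the oral route; a lower number here means less inhibition, a higher number more inhibition at the dose given (going by the name of the read-out). Compound 1 `O=C1N=C(C2C(=O)c3ccccc3C2=O)CC(c2ccccc2[N+](=O)[O-])N1` gives 32%, compound 2 `O=C1N=C(C2C(=O)c3ccccc3C2=O)CC(c2ccccc2)N1` gives 11%, and compound 3 `O=C1N=C(C2C(=O)c3ccccc3C2=O)CC(c2ccc([N+](=O)[O-])cc2)N1` gives 18%. Compound 3 thus stands second highest of the three: a number 14 percentage points lower from compound 1 to compound 3 (beyond the scatter), whereas a number 7 percentage points higher from compound 2 to compound 3 (within the scatter). Compound 4 `O=C1N=C(C2C(=O)c3ccccc3C2=O)CC(/C=C/c2ccccc2)N1` differs from compound 3 by 2-phenylethenyl in place of 4-nitrophenyl on a saturated ring carbon. Among the measured compounds shown here, no measured step exchanges 4-nitrophenyl for 2-phenylethenyl; the nearest guide is the loss of the nitro group, where a number 7 percentage points higher from compound 2 to compound 3 (within the scatter) remained within the scatter, while a number 21 percentage points lower from compound 1 to compound 2 (beyond the scatter) concerned compound 1 with its 2-nitrophenyl. One therefore expects no step beyond the scatter in this assay, the estimated change being a number 5 percentage points lower from compound 3 to compound 4 (within the scatter). Compound 4 is expected to give 13%, between 2% and 28%.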

Compound 4, a percentage reported as inhibition, in the whole organism at one dose (the size of the read-out at that dose, not a potency): 16%
Estimate against measurement, compound 4: 3 percentage points below, within the range that was stated.
By their numbers in this assay, from the lowest: compounds 2, 4 and 3 (each within the scatter of the next); then compound 1.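

In this assay, 2-phenylethenyl on this saturated ring carbon gives a number 2 percentage points lower from compound 3 to compound 4 (within the scatter) and a number 5 percentage points higher from compound 2 to compound 4 (within the scatter) while a number 16 percentage points lower from compound 1 to compound 4 (beyond the scatter) marks the one clear gap. An aromatic ring bonded directly to this carbon is therefore not required to keep the number level with those of compound 2 and compound 3, and among these four only compound 1 with its 2-nitrophenyl stands apart. No available evidence accounts for this. Still open, on these data alone, is whether an amine or a carboxylic acid on the aromatic ring, or a longer chain on this carbon, would match compound 1.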